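Glycinamide Esters Compared in Tail Flick Activity

A few compounds are considered here, and "the series" means these few. Any claim that something is new, unique, unknown or untested is made for them only; others in the source may bear on it.

Measured compounds:
compound 1 `C[C@H](NC(=O)CN(c1nc(Cl)nc2[nH]cnc12)C1CC1)C(=O)OCc1ccccc1` gives 44.2%
compound 2 `O=C(CN(c1ncnc2c1ncn2C1CCCCO1)C1CC1)N[C@@H](CCC(=O)OCc1ccccc1)C(=O)OCc1ccccc1` gives 25.2%
compound 3 `O=C(OCc1ccccc1)[C@@H]1CCCN1C(=O)CN(c1nc(Cl)nc2[nH]cnc12)C1CC1` gives 43.3%

The three measured compounds were tested in a functional assay on the whole organism (Tail, strain ICR) with Mus musculus as the target, in the tail flick test, with a stated time of 90 min, at a dose of 25 umol/kg by the oral route; on this read-out lower numbers stand for a weaker effect and higher numbers for a stronger effect at the one dose given. Compound 2 stands lowest of the three numbers; compound 3 lies higher, and compound 1 higher still, and both of those gaps are beyond the usual scatter. Compounds 1 and 3 lie within the scatter of each other, so no order between them can be claimed.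

Compound 4 `CC[C@H](C)[C@H](NC(=O)CN(c1ncnc2c1ncn2C1CCCCO1)C1CC1)C(=O)OCc1ccccc1` has not been measured in this assay. Going by the values given here, its only difference from compound 2 is this: sec-butyl in place of 2-(benzyloxycarbonyl)ethyl on a saturated chain carbon bound to an amide-type nitrogen and a carbonyl carbon. Among the compounds with values here, no measured pair of compounds differs in this single way, so the direction of the step must be guessed from the structures alone. Compound 4 keeps the core of compound 2 and shortens the chain, and the account expects a modest rise, a step from compound 2 to compound 4 of about a number 9.8 percentage points higher from compound 2 to compound 4 (within the scatter) in this assay, roughly at the edge of the scatter. The estimate for compound 4 is therefore 35%, with a likely range from 15% to 55%.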

Compound 4, a percentage reported as activity, at one dose (the size of the read-out at that dose, not a potency): 22.6%
The estimate for compound 4 lay 12.4 percentage points above the measured number; the measured number falls inside the stated range.
By their numbers in this assay, from the lowest: compounds 4 and 2 (each within the scatter of the next); then compounds 3 and 1 (each within the scatter of the next).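

Exchanging the 2-(benzyloxycarbonyl)ethyl group for sec-butyl on this saturated chain carbon gives a number 2.6 percentage points lower from compound 2 to compound 4 (within the scatter) in this assay. On this core, therefore, a far smaller chain without the aromatic ring leaves the read-out within the usual scatter, so this change at this position shows no effect at the one dose and time tested. Nothing available here explains why the two numbers stand so close.

From the compounds shown here alone, it remains open whether a carboxylic acid or an amine on this chain carbon would also leave the read-out unmoved, since both compounds carry only carbon-based side chains at this place. Going by these compounds, it is equally open whether sec-butyl would behave the same way on the core of compound 1.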